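Chloro on the 2-phenyl of the shared core

The compounds below may be only part of what the source reports. "The series", "measured", "known", "first", "only" and "open" are said of these compounds alone.

Measured in a functional assay for antagonist activity at Adrenergic receptor alpha-1 (Rattus norvegicus); a higher number here means weaker binding, a lower number tighter binding:
compound 1 `O=c1cc(-c2ccccc2)oc2cc(OCCCCN3CCN(c4ccccc4)CC3)ccc12` gives 4.65 nM
compound 2 `Cc1ccc(N2CCN(CCCCOc3ccc4c(=O)cc(-c5ccccc5)oc4c3)CC2)cc1` gives 195 nM
compound 3 `Cc1ccccc1N1CCN(CCCCOc2ccc3c(=O)cc(-c4ccccc4)oc3c2)CC1` gives 19.5 nM

Compound 1 stands lowest of the three. Its nearest neighbour is compound 3, reached by a 4.2-fold higher number from compound 1 to compound 3 (0.62 log units; beyond the scatter); its furthest is compound 2, reached by a 42-fold higher number from compound 1 to compound 2 (1.62 log units; beyond the scatter). Between the two methyl analogues the step is a 10-fold lower number from compound 2 to compound 3 (1.00 log units; beyond the scatter).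

Compound 4 `O=c1cc(-c2ccc(Cl)cc2)oc2cc(OCCCCN3CCN(c4ccccc4)CC3)ccc12` differs from compound 1 by chloro in place of hydrogen on an aromatic carbon. Among the compounds with values here, every measured step concerns the phenyl on the piperazine nitrogen; no step touches the ring where the chloro enters, so none bears directly on this change. With no comparable change in hand, the expectation is a small step, within or just beyond the scatter, in either direction.

Compound 4 is expected to give 6 nM, with a range from 2 nM to 25 nM. The expected step is a 1.3-fold higher number from compound 1 to compound 4 (0.11 log units; within the scatter).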

Compound 4, dissociation constant: 12.2 nM
Estimate against measurement, compound 4: 2.0-fold (0.31 log units) below; low and high end bracket the measured number.
By their numbers in this assay, from the lowest: compound 1; then compounds 4 and 3 (each within the scatter of the next); then compound 2.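

In this assay, within the data shown here, the ring carrying phenyl on the shared core responds to substitution, which the earlier compounds could not show: phenyl to 4-chlorophenyl gives a step beyond the scatter (a 2.6-fold higher number from compound 1 to compound 4 (0.42 log units; beyond the scatter)). At this place, chloro brings no gain over the hydrogen of compound 1. No measurement in hand accounts for this step.

As far as these compounds go, whether the step belongs to chloro or to any group at this place remains open. Fluoro, methyl or methoxy on the same carbon would separate the two readings.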